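This account rests on a few compounds, and the source may have more. Where it says the series, first, only, none or still open, it means among the compounds named here.

Among the measured compounds shown here, in an ADME assay on LLC-PK1 cells (Sus scrofa) for permeability, read by LC-MS, with a stated time of 2 h, tested at 5 uM (on this read-out lower numbers stand for lower permeability and higher numbers for higher permeability), compound 1 `CC#Cc1cncc(-c2ccc3c(c2)[C@@]2(COC(N)=N2)c2cc(-c4ccnc(F)c4)ncc2O3)c1` gives 15 nm/s and stands as the lower of the two numbers so far. Compound 2 `Cc1cc2c(cn1)Oc1ccc(NC(=O)c3ccc(Cl)cn3)cc1[C@@]21COC(N)=N1` gives 40 nm/s as the higher number, a gap beyond the scatter. Compound 3 `CC#Cc1cncc(-c2ccc3c(c2)[C@@]2(COC(N)=N2)c2cc(C4=CCCOC4)ncc2O3)c1` is not yet measured and differs from compound 1 in one place, with a group of 6 heavy atoms (5 carbon, 1 oxygen; one six-membered non-aromatic ring with 1 hetero atom) in place of a group of 7 heavy atoms (5 carbon, 1 nitrogen, 1 fluorine; one six-membered aromatic ring with 1 hetero atom), on an aromatic carbon on an aromatic carbon. For the measured compounds named here, no measured pair covers such a change, so only a small rise in this assay is expected, close to the scatter. The expected change is a 1.7-fold higher number from compound 1 to compound 3 (0.22 log units; within the scatter) on present evidence. For compound 3 the estimated value is 25 nm/s with an expected range of 10 nm/s to 60 nm/s for this read-out.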

Compound 3, apparent permeability: 19 nm/s
The estimate for compound 3 lay 1.3-fold (0.12 log units) above the measured number; the range from low to high includes it.
By their numbers in this assay, from the lowest: compounds 1 and 3 (each within the scatter of the next); then compound 2.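

In this assay, the group with a six-membered non-aromatic ring with 1 hetero atom and 1 double bond outside aromatic rings, in place of 2-fluoropyridin-4-yl next to the ring nitrogen, gives a 1.3-fold higher number from compound 1 to compound 3 (0.10 log units; within the scatter). For this pair, then, the aromatic ring at this position can be exchanged without a step beyond the scatter. Nothing measured accounts for the two groups reading alike.

As far as these compounds go, whether an amine, a carboxylic acid or a longer chain on this carbon would give a step beyond the scatter remains open. Compound 2 differs from the others in more than one place and says nothing about this position.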